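The compounds below may be only part of what the source reports. "The series", "measured", "known", "first", "only" and "open" are said of these compounds alone.

Measured in a physicochemical assay for permeability, using PAMPA; a higher number here means that the compound crosses the layer faster, a lower number that the compound crosses the layer more slowly:
Compound 1 `Cc1ccc([C@@H](C)Oc2cc3oc(=O)n(CCC(=O)O)c3cc2Cl)nc1`: 22 nm/s
Compound 2 `O=C(O)CCn1c(=O)oc2cc(Cl)c(Cl)cc21`: 24 nm/s

Compound 2, the smaller of the two structures, gives 24 nm/s in this assay. Compound 1 gives 22 nm/s, and the two numbers lie within the scatter of each other. The next structure, compound 3 `O=C(O)CCn1c(=O)oc2cc(OCc3ccccn3)c(Cl)cc21`, departs from compound 2 at a single place: (pyridin-2-yl)methoxy in place of chloro on an aromatic carbon. In words, (pyridin-2-yl)methoxy stands in place of chloro on an aromatic carbon, ortho to a chloro group.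

Among the measured compounds shown here, no measured pair differing in one place shows what such an exchange does, so the expectation rests on thin ground. The closest guide is compound 1, which also has a larger ether group where compound 2 has chloro. Compound 1 gives 22 nm/s. No step beyond the scatter is therefore expected in this assay, with only a slight lean towards a lower number. The estimated change is a 1.2-fold lower number from compound 2 to compound 3 (0.08 log units; within the scatter). For compound 3 the expected value is 20 nm/s, within an estimated range of 9 nm/s to 42 nm/s.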

Compound 3, apparent permeability: 11 nm/s
The estimate for compound 3 lay 1.8-fold (0.26 log units) above the measured number; low and high end bracket the measured number.
By their numbers in this assay, from the lowest: compounds 3, 1 and 2 (each within the scatter of the next, the first and the last beyond it).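

In this assay, the exchange of chloro for (pyridin-2-yl)methoxy on this aromatic carbon, ortho to a chloro group, gives a 2.2-fold lower number from compound 2 to compound 3 (0.34 log units; beyond the scatter). Among the compounds shown here, this is the first step between measured compounds that differ in one place, and it shows that the read-out responds to what stands at this position, although the step is modest and lies only just beyond the scatter. The change removes a single chlorine and brings in eight heavy atoms, a six-membered aromatic ring with one hetero atom and two hydrogen-bond acceptors, and nothing at hand explains the step or ties it to any one of these features.

On these data alone, what remains open is which part of the entering group goes with the lower number: the ring nitrogen, the ether oxygen or simply the larger group, a question that a methoxy or a benzyloxy group on the same carbon would help to separate. As far as these compounds go, it is also open whether a step of this size would recur on the same carbon with an amine-bearing ether or a longer chain between the oxygen and the ring.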